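This account rests on a few compounds, and the source may have more. Where it says the series, first, only, none or still open, it means among the compounds named here.

Working notes on a small set in a functional assay on the whole organism (strain Wistar) for inhibition, with Rattus norvegicus as the target, with a stated time of 5 days, at a dose of 50 mg/kg by the oral route; a lower number here means less inhibition, a higher number more inhibition at the dose given (going by the name of the read-out). Compound 1 `COc1ccc2cc(C(C)CC(C)=O)ccc2c1` carries a methoxy group on the shared core and a methyl-branched chain; in this assay compound 1 gives 24%. Compound 2 `CC(=O)CCc1ccc2cc(C)ccc2c1` carries a methyl group on the core and an unbranched chain; in this assay compound 2 gives 34%. Compound 2 sits at the top of the two numbers, but its gap to compound 1 lies within the scatter and carries no ranking. Compound 3 `CC(=O)CC(C)c1ccc2cc(C)ccc2c1` has not been measured. It differs from compound 2 by methyl in place of hydrogen on a saturated chain carbon bound to an aromatic carbon and a saturated chain carbon. Going by the values given here, no measured pair isolates this change; the nearest comparison is compound 1, which also bears the branch beside a different ring group and gives 24%. The expected step in this assay is a number 4 percentage points lower from compound 2 to compound 3 (within the scatter), small and with no direction beyond the scatter. The estimate for compound 3 is 30%, expected between 12% and 48%.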

Compound 3, a percentage reported as inhibition, in the whole organism at one dose (the size of the read-out at that dose, not a potency): 11%
The estimate for compound 3 lay 19 percentage points above the measured number; measured number below the stated range.
By their numbers in this assay, from the lowest: compound 3; then compounds 1 and 2 (each within the scatter of the next).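

In this assay, going by these compounds alone, methyl in place of hydrogen on a saturated chain carbon bound to an aromatic carbon and a saturated chain carbon gives a number 23 percentage points lower from compound 2 to compound 3 (beyond the scatter), the first step that isolates this change. With that chain methyl common to both compounds, methyl in place of methoxy on an aromatic carbon gives a number 13 percentage points lower from compound 1 to compound 3 (beyond the scatter), so the read-out at this dose responds to a change on the chain and to a change on the core. Nothing available explains either step.

The compounds shown include no unbranched counterpart of compound 1, so it remains open whether the chain methyl has a similar effect with methoxy on the core. Also open, going by these compounds, is how ethyl on the same chain carbon, or a carboxylic acid in place of the ketone, would read out.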